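Swapping the Amide Aryl Group for a Pyrimidine

The source may hold more compounds than are shown below. What is called first, only, known or untested is meant among the compounds shown, and "the series" means these compounds.

Compound 1 `COc1ccc2nc(C)cc(OCC(=O)Nc3cc(C)cc(C)c3)c2c1`: 5.64
Compound 2 `CSc1ccc2nc(C)cc(OCC(=O)Nc3cc(C)cc(C)c3)c2c1`: 6.42
Compound 3 `CCOc1ccc2nc(C)cc(OCC(=O)Nc3cc(C)cc(C)c3)c2c1`: 5.98

In a physicochemical assay for lipophilicity, read by HPLC, in phosphate buffer, measured as chromatographic lipophilicity, at pH 7.4 (a lower number here means a more polar compound, a higher number a more lipophilic compound), compound 1 stands lowest of the three numbers. Its nearest neighbour is compound 3, reached by a number 0.34 log units higher from compound 1 to compound 3 (beyond the scatter); the furthest is compound 2, reached by a number 0.78 log units higher from compound 1 to compound 2 (beyond the scatter). Compound 4 `COc1ccc2nc(C)cc(OCC(=O)Nc3ccncn3)c2c1` is not yet measured. It differs from compound 1 at the amide-type nitrogen: pyrimidin-4-yl in place of 3,5-dimethylphenyl on an amide-type nitrogen. Among the measured compounds shown here, none of the measured steps touches this position; all three change the group on the aromatic carbon of the shared core, so they show only that those changes were modest. The new change replaces eight heavy atoms carrying no hydrogen-bond acceptors with six heavy atoms carrying two, so a downward step well beyond the scatter is expected, a number 2.34 log units lower from compound 1 to compound 4 (beyond the scatter). Compound 4 is therefore estimated at 3.3, between 2.6 and 4.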

Compound 4, distribution coefficient: 2.53
The estimate for compound 4 lay 0.77 log units above the measured number; measured number outside the range, below it.
By their numbers in this assay, from the lowest: compound 4; then compound 1; then compound 3; then compound 2.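

In this assay, pyrimidin-4-yl in place of 3,5-dimethylphenyl on an amide-type nitrogen gives a number 3.11 log units lower from compound 1 to compound 4 (beyond the scatter) and this large step shows that the group on this nitrogen can move the number much further than the modest changes on the aromatic carbon of the shared core. No measurement at hand accounts for the size of this step. The compounds leave open how much of it belongs to the ring nitrogens and how much to the loss of the two methyl groups, a question on which an unsubstituted phenyl or a pyridin-4-yl on the same nitrogen would bear. Going by these compounds, whether the step holds with methylsulfanyl or ethoxy on the core also remains open.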